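This account rests on a few compounds, and the source may have more. Where it says the series, first, only, none or still open, it means among the compounds named here.

The measured compounds:

Compound 1, `COc1ccc(-c2cc(=O)c3c(OC)cc(OC)cc3n2S(=O)(=O)c2cccc(Br)c2)cc1`. In a functional assay on HepG2 cells (Homo sapiens) for antiproliferative activity, with a stated time of 72 h (a lower number here means that less compound is needed, a higher number that more compound is needed for the effect), compound 1 reaches only the assay limit, > 58600 nM.

Compound 2, `COc1ccc(-c2cc(=O)c3c(OC)cc(OC)cc3n2S(=O)(=O)Cc2ccccc2)cc1`. In this assay compound 2 likewise reaches only the assay limit, > 34400 nM.

Going by the values given here, compound 2 therefore stands at a limit rather than at a number, and the one other value shown, that of compound 1, is a limit as well. The step that the two limits leave unreadable from compound 1 to compound 2 cannot be read between the two limits, as the limit of > 34400 nM in this assay, at which 1 of the 2 values shown sits, and the limit of > 58600 nM in this assay, at which 1 of the 2 values shown sits, show.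

Compound 3, `COc1ccc(-c2cc(=O)c3c(OC)cc(OC)cc3n2S(=O)(=O)c2ccc(Br)s2)cc1`, differs from compound 2 in one place: 5-bromothiophen-2-yl in place of benzyl on a sulfonyl sulfur. Among the compounds with values here, the only measured step that touches the group on the sulfonyl sulfur is a step that the two limits leave unreadable from compound 1 to compound 2, and it gives neither a size nor a direction, so no step beyond the scatter can be predicted in this assay from it. Because compound 2 sits at the limit of > 34400 nM in this assay, at which 1 of the 2 values shown sits, compound 3 is expected to show a step that the limit leaves unreadable from compound 2 to compound 3, meaning it most likely also sits at a limit. Compound 3 is accordingly estimated at 50000 nM, within 10000 nM to 200000 nM.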

Compound 3, half-maximal effective concentration: > 48200 nM
Compound 3 was reported as a limit (the forecaster's own chance of this, stated with the estimate: 85%); the middle value is on the limit's open side.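

Compound 1, compound 2 and compound 3 all reach only a limit in this assay, so no step can be read among them. The compounds shown leave open where any of the three would fall as an actual number, and whether the group on the sulfonyl sulfur changes the antiproliferative effect at all.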